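The compounds below may be only part of what the source reports. "The series", "measured", "known", "first", "only" and "open" are said of these compounds alone.

Measured compounds in a functional assay on cells (Leukemia cell, Homo sapiens) for cytotoxicity, with a stated time of 48 h; on this read-out lower numbers stand for stronger inhibition of growth and higher numbers for weaker inhibition of growth:
- compound 1 `COc1cc2c(/C=C3/C(=O)Nc4ccc(Cl)cc43)c(Cl)n(Cc3cc(OC)c(OC)c(OC)c3)c2cc1C` gives 1860 nM
- compound 2 `COc1cc2c(/C=C3/C(=O)Nc4cccc(Cl)c43)c(Cl)n(Cc3cc(OC)c(OC)c(OC)c3)c2cc1C` gives 2450 nM
- compound 3 `COc1ccc2c(c1)/C(=C\c1c(Cl)n(C/C=C/c3ccccc3)c3ccccc13)C(=O)N2` gives 2000 nM

Compound 1 has the lowest of the three numbers, but its nearest neighbour compound 3 and its furthest neighbour compound 2 both sit within the scatter of it, so no ordering among the three can be claimed.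

The step of interest leads to compound 4 `COc1ccc2c(c1)/C(=C\c1c(Cl)n(Cc3cc(OC)c(OC)c(OC)c3)c3cc(C)c(OC)cc13)C(=O)N2`, which differs from compound 1 by methoxy in place of chloro on an aromatic carbon, the place being on an aromatic carbon of a six-membered aromatic ring of carbon only, part of a fused or bridged system of two rings.

Among the compounds with values here, only one single-point step is available in this assay: a 1.3-fold higher number from compound 1 to compound 2 (0.12 log units; within the scatter), where the chloro on the same fused system was moved rather than replaced. Compound 3 carries the same methoxy-bearing fused system as compound 4, yet differs from compound 1 in more than one place, so only its value can be noted: compound 3 gives a number within the scatter of compound 1. Nothing here points to a step beyond the scatter in either direction for this assay. The expected step is a 1.0-fold higher number from compound 1 to compound 4 (0.01 log units; within the scatter), essentially flat. For compound 4 the estimate is 1900 nM, with a range from 900 nM to 4000 nM.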

Compound 4, concentration for 50% growth inhibition: 6170 nM
Compound 4: the middle estimate sits 3.2-fold (0.51 log units) below what was measured; the whole stated range lies below it.
By their numbers in this assay, from the lowest: compounds 1, 3 and 2 (each within the scatter of the next); then compound 4.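

In this assay, within the data shown here, this aromatic carbon of the fused system of two rings is the first place where a single change goes beyond the scatter: methoxy in place of chloro gives a 3.3-fold higher number from compound 1 to compound 4 (0.52 log units; beyond the scatter) as a modest loss of growth inhibition. Among these compounds, the only earlier single-point step, a 1.3-fold higher number from compound 1 to compound 2 (0.12 log units; within the scatter), moved the chloro on the same fused system and showed no separable change, so the series is not flat to every change on this ring system. The result rests on one pair of compounds, and no measurement here bears on what lies behind the step.

Still open is whether the weaker inhibition follows from the arrival of methoxy or from the departure of chloro: only one replacement for chloro at this place is shown, and hydrogen, fluoro, an amine or a longer alkoxy chain there would help to separate the two readings. Also open, as far as these compounds go, is whether the same exchange gives a step of similar size when the rest of the molecule differs.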